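Removing the chloro from the anilide ring of compound 1

This account rests on a few compounds, and the source may have more. Where it says the series, first, only, none or still open, it means among the compounds named here.

For the measured compounds named here, compound 1 `CCOC(=O)c1c(NC(=O)CC#N)sc(C(=O)Nc2ccc(Cl)cc2)c1-c1ccccc1` gives the lower of the two numbers so far in a functional assay on A549 cells (Homo sapiens) for inhibition, read by MTT assay (on this read-out lower numbers stand for stronger inhibition and higher numbers for weaker inhibition), with 600 nM; its nearest neighbour, compound 2 `N#CCC(=O)Nc1sc(C(=O)Nc2ccc(Cl)cc2)c(-c2ccccc2)c1C#N`, gives 1400 nM, and the step of a 2.3-fold higher number from compound 1 to compound 2 (0.37 log units; beyond the scatter) is the only measured one. Compound 3 `CCOC(=O)c1c(NC(=O)CC#N)sc(C(=O)Nc2ccccc2)c1-c1ccccc1` differs from compound 1 in a single place: hydrogen in place of chloro on an aromatic carbon. Going by the values given here, no measured step touches this position, since the one available step concerns a different group on the shared core, so it offers no direct guide to the size or direction of the change. With no evidence that this chloro carries the potency, the expected outcome is a step of a 1.5-fold higher number from compound 1 to compound 3 (0.18 log units; within the scatter), small and within the usual scatter of this assay, though a modest loss cannot be ruled out. Compound 3 is therefore estimated at 900 nM, within a range of 350 nM to 2500 nM.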

Compound 3, half-maximal inhibitory concentration: 320 nM
The estimate for compound 3 lay 2.8-fold (0.45 log units) above the measured number; the measured number lies below the stated range.
By their numbers in this assay, from the lowest: compounds 3 and 1 (each within the scatter of the next); then compound 2.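

In this assay, replacing the chloro with hydrogen on the six-membered aromatic ring gives a 1.9-fold lower number from compound 1 to compound 3 (0.27 log units; within the scatter) and so leaves the two compounds indistinguishable on this read-out. The chloro of the 4-chlorophenyl group is therefore not needed for a number in the range of compound 1, and this position accepts plain phenyl on the shared core. Nothing measured here explains this result or tells what the chloro does at this position.

For the compounds shown here, only chloro and hydrogen can be compared at this position so far, so it remains open whether a methoxy group, an amine or a carboxylic acid there would move the number beyond the scatter. On these data alone, it is also open whether cyano in place of ethoxycarbonyl would give a similar step in a compound carrying phenylcarbamoyl instead of (4-chlorophenyl)carbamoyl.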